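The source may report more compounds than this note shows. Statements on the series, on what has been measured and on what is new or still open speak of the compounds shown alone.

The measured compounds in an ADME assay on Caco-2 cells (Homo sapiens) for permeability, in the apical to basolateral direction; on this read-out lower numbers stand for lower permeability and higher numbers for higher permeability:
Compound 1, `Cn1cncc1CN1CC(N(CC2CCN(C(=O)OC(C)(C)C)CC2)S(=O)(=O)c2ccccn2)Cc2cc(C#N)ccc21`, gives 15.5 10^-6 cm/s.
Compound 2, `Cc1noc(C)c1CN(C1Cc2cc(C#N)ccc2N(Cc2cncn2C)C1)S(=O)(=O)c1ccccn1`, gives 8 10^-6 cm/s.
Compound 3, `CC(=O)N1CCC(CN(C2Cc3cc(C#N)ccc3N(Cc3cncn3C)C2)S(=O)(=O)c2ccccn2)CC1`, gives 0.5 10^-6 cm/s.

Compound 3 stands lowest of the three numbers: the step of a 16-fold lower number from compound 2 to compound 3 (1.20 log units; beyond the scatter) and the step of a 31-fold lower number from compound 1 to compound 3 (1.49 log units; beyond the scatter) both lie beyond the scatter, so compound 3 is the least permeable of the measured set. Compound 4, `CC(C)C(=O)N1CCC(CN(C2Cc3cc(C#N)ccc3N(Cc3cncn3C)C2)S(=O)(=O)c2ccccn2)CC1`, differs from compound 3 in one place: isopropyl in place of methyl on a carbonyl carbon. Of the measured steps, a 31-fold lower number from compound 1 to compound 3 (1.49 log units; beyond the scatter) bears most directly on this change, since it too exchanges the group on the carbonyl carbon, and there the smaller methyl gave the far lower number. The step of a 16-fold lower number from compound 2 to compound 3 (1.20 log units; beyond the scatter) also ends at compound 3 with a large drop. Both steps suggest that enlarging the group on that carbonyl carbon should move the number back upward; the change from methyl to isopropyl is, however, smaller than the change seen in a 31-fold lower number from compound 1 to compound 3 (1.49 log units; beyond the scatter), so a moderate upward step in this assay is expected rather than a full return. For compound 4 the expected step is a 3.0-fold higher number from compound 3 to compound 4 (0.48 log units; beyond the scatter). Compound 4 is therefore estimated at 1.5 10^-6 cm/s, with a range from 0.5 10^-6 cm/s to 5 10^-6 cm/s.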

Compound 4, apparent permeability: 0.5 10^-6 cm/s
Compound 4: the middle estimate sits 3.0-fold (0.48 log units) above what was measured, within the range that was stated.
By their numbers in this assay, from the lowest: compounds 3 and 4 (each within the scatter of the next); then compounds 2 and 1 (each within the scatter of the next).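

In this assay, placing isopropyl instead of methyl on the carbonyl carbon, whose other neighbour is the amide-type nitrogen in a ring, gives no change at the digits printed from compound 3 to compound 4 (within the scatter), so the two extra carbons of this branched group do not separate the compounds at this position. The large gaps to the two higher compounds remain with isopropyl in place: tert-butoxy on the same carbonyl carbon stands apart in a 31-fold lower number from compound 1 to compound 4 (1.49 log units; beyond the scatter), and the exchange of 3,5-dimethyl-1,2-oxazol-4-yl for 1-(isopropylcarbonyl)piperidin-4-yl gives a 16-fold lower number from compound 2 to compound 4 (1.20 log units; beyond the scatter), matching what the acetyl compound showed. No evidence is at hand that gives a cause for these results.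

As far as these compounds go, what stays open is whether the higher number of compound 1 goes with the oxygen of tert-butoxy or with its branched carbons, a question that a tert-butyl or a methoxy group on the same carbonyl carbon would address. Also open, from the compounds shown here alone, is how this read-out would respond to a different kind of group on that carbonyl carbon, such as an amine or a longer chain, or to removal of the carbonyl to leave a piperidine amine.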